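A few compounds are considered here, and "the series" means these few. Any claim that something is new, unique, unknown or untested is made for them only; others in the source may bear on it.

Going by the values given here, in a functional assay on HGC-27 cells (Homo sapiens) for inhibition, read by MTT assay, with a stated time of 72 h (on this read-out lower numbers stand for stronger inhibition and higher numbers for weaker inhibition), compound 1 (`O=C(NCc1ccc(NC(=O)c2cc(-c3ccccc3)ccc2N2CCCC2)cc1)OCc1cccnc1`) gives 4340 nM, the highest number among the three compounds measured so far and therefore the weakest inhibition of the set. Compound 2 (`O=C(NCc1ccc(NC(=O)c2ccc(F)cc2N2CCCC2)cc1)OCc1cccnc1`) gives 1840 nM and compound 3 (`Cc1cccc(C(=O)Nc2ccc(CNC(=O)OCc3cccnc3)cc2)c1N1CCCC1`) gives 1030 nM. Both numbers lie lower than that of compound 1 by more than the usual scatter, while the two lie within the scatter of each other.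

Compound 4 (`O=C(NCc1ccc(NC(=O)c2cc(Cl)ccc2N2CCCC2)cc1)OCc1cccnc1`) has not yet been measured. It differs from compound 1 by a single change, chloro in place of phenyl on an aromatic carbon, meta to a large group and para to a pyrrolidin-1-yl group: chloro in place of phenyl on an aromatic carbon.

Among the compounds with values here, no pair of measured compounds differs in one place only, so the size of this change cannot be read directly from the data. The expectation rests instead on the phenyl-bearing compound 1 at 4340 nM standing above compound 2 at 1840 nM and compound 3 at 1030 nM, neither of which carries that phenyl. A moderate move toward stronger inhibition is therefore expected, and the estimated step is a 2.4-fold lower number from compound 1 to compound 4 (0.38 log units; beyond the scatter). For compound 4 the expected value is 1800 nM, with an estimated range of 800 nM to 4000 nM.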

Compound 4, half-maximal inhibitory concentration: 750 nM
The estimate for compound 4 lay 2.4-fold (0.38 log units) above the measured number; the whole stated range lies above it.
By their numbers in this assay, from the lowest: compounds 4, 3 and 2 (each within the scatter of the next, the first and the last beyond it); then compound 1.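

In this assay, going by these compounds alone, the one step between compounds that differ in a single place is a 5.8-fold lower number from compound 1 to compound 4 (0.76 log units; beyond the scatter), so the effect of a change at this position can now be read directly. On the aromatic carbon para to a pyrrolidin-1-yl group, chloro, a single chlorine atom, replaces phenyl, a six-membered aromatic ring of carbon only, and inhibition becomes stronger by more than the usual scatter, which shows that the phenyl is not required for inhibition in this assay. Nothing measured here accounts for the size of this step.

The compounds shown leave open whether the step reflects the arrival of chloro or the departure of phenyl; a hydrogen, a bromo or a methoxy group on this same carbon would tell these apart. They also leave open whether the step would persist with another part of the molecule changed, for instance with a piperidine in place of the pyrrolidin-1-yl group.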